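Swapping a Hydroxyl Chain End for Trifluoromethyl: Cytotoxicity

The source may report more compounds than this note shows. Statements on the series, on what has been measured and on what is new or still open speak of the compounds shown alone.

Of the compounds shown here, three have so far been tested in an ADME assay on HEp-2 cells (Homo sapiens) for cytotoxicity, with a stated time of 4 days; on this read-out lower numbers stand for higher toxicity in this test and higher numbers for lower toxicity in this test. Compound 1 `CS(=O)(=O)CCn1c(Cn2cc(S(C)(=O)=O)c3ccccc32)nc2cc(Cl)ccc21` gives only a limit, > 100000 nM. Compound 2 `CCS(=O)(=O)c1cn(Cc2nc3cc(Cl)ccc3n2CCCS(C)(=O)=O)c2ccccc12` likewise reaches only the limit of > 100000 nM. Compound 3 `CC(C)(O)CCn1c(Cn2nc(S(C)(=O)=O)c3ccncc32)nc2cc(Cl)ccc21` also stands at a limit, > 100000 nM, so it sits alongside the other two with no toxicity seen within the reach of this assay; the evidence so far is simply (the limit of > 100000 nM in this assay, at which 3 of the 3 values shown sit). Compound 4 `CS(=O)(=O)c1nn(Cc2nc3cc(Cl)ccc3n2CCC(F)(F)F)c2cnccc12` is not yet measured and differs from compound 3 by trifluoromethyl in place of 1-hydroxy-1-methylethyl on a saturated chain carbon, two bonds along the chain from an aromatic nitrogen. For the measured compounds named here, no measured step exists for this change, and with every value at the limit the step is expected to be a step that the limit leaves unreadable from compound 3 to compound 4, nothing beyond the scatter. Compound 4 is therefore expected to give 150000 nM, with a range from 60000 nM to 400000 nM, most likely again reported only as a limit.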

Compound 4, half-maximal cytotoxic concentration: > 100000 nM
Compound 4 gave a limit, no number; the forecaster's own chance of this, stated with the estimate: 85%; the middle value lies beyond the limit too.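

In this assay compound 3 and compound 4 both stop at a limit, so no size can be read for the swap between them. Where any of these compounds would begin to harm the cells stays open: the limit of > 100000 nM in this assay, at which 4 of the 4 values shown sit.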